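A few compounds are considered here, and "the series" means these few. Any claim that something is new, unique, unknown or untested is made for them only; others in the source may bear on it.

Compound 1 `COCOc1cc(C2=C(c3cc(OC)c(OC)c(OC)c3)C(=O)CC2O[SiH2]C(C)(C)C)ccc1OC` gives 50 ug/mL in an ADME assay on MIA PaCa-2 cells (Homo sapiens) for cytotoxicity, read by MTT assay, with a stated time of 72 h; on this read-out higher numbers stand for weaker inhibition and lower numbers for stronger inhibition.
Compound 2 `COc1cc(C2=C(c3cc(C)c(OC)c(C)c3)C(OC(C)=O)CC2=O)cc(OC)c1OC` gives > 100 ug/mL in this assay, which is a limit of the assay rather than a number.

Among the measured compounds shown here, compound 1 holds the only numeric value here; the other result is the limit of > 100 ug/mL in this assay, at which 1 of the 2 values shown sits. Compound 3 `COc1ccc(C2=C(c3cc(OC)c(OC)c(OC)c3)C(=O)CC2O[SiH2]C(C)(C)C)cc1O` differs from compound 1 by hydrogen in place of methoxymethyl on an oxygen on an aromatic ring. For the measured compounds named here, no step between two measured compounds is available to gauge this change, so the expected step from compound 1 to compound 3 is set at none beyond the usual scatter, meaning no change at the digits printed from compound 1 to compound 3 (within the scatter). Compound 3 is therefore expected to give about 50 ug/mL in this assay, within a range from 20 ug/mL to 120 ug/mL.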

Compound 3, half-maximal inhibitory concentration: 55 ug/mL
Compound 3: middle estimate off by 1.1-fold (0.04 log units), on the low side, and the stated range covers the measured number.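

Swapping methoxymethoxy for hydroxy on the aromatic ring gives a 1.1-fold higher number from compound 1 to compound 3 (0.04 log units; within the scatter) in this assay, so this is the first measured change at this oxygen, and the two groups cannot be told apart here. The oxygen can therefore carry either hydrogen or methoxymethyl with no change in the read-out beyond normal repeat variation. Nothing shown accounts for this outcome.

Going by these compounds, whether a plain methyl, a longer chain such as butyl, or an amine at this place would also leave the number in the same range stays open.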